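Trimming the Alkyl Chain of Compound 1: What to Expect

This account rests on a few compounds, and the source may have more. Where it says the series, first, only, none or still open, it means among the compounds named here.

Compound 1 `CCCCCCCCCCn1cc(/C=C/C(=O)c2ccc(NC(=O)CN3CCC(Cc4ccccc4)CC3)cc2)nn1` gives 67700 nM in a functional assay on A549 cells (Homo sapiens) for inhibition, read by MTT assay; on this read-out higher numbers stand for weaker inhibition and lower numbers for stronger inhibition.
Compound 2 `CCCCCCCCCCn1cc(/C=C/C(=O)c2ccc(NC(=O)CBr)cc2)nn1` gives 9740 nM in this assay.
Compound 3 `CCCCCCCCn1cc(/C=C/C(=O)c2ccc(NC(=O)CBr)cc2)nn1` gives 11600 nM in this assay.

Compound 1 shows the highest of the three numbers, and its values stand beyond the scatter from those of compound 2 and compound 3. The difference between the core of compound 1 and the core shared by compound 2 and compound 3 is not broken down here. Compound 3 arises from compound 2 by hydrogen in place of ethyl on a saturated chain carbon, eight bonds along the chain from an aromatic nitrogen, and that step produced a 1.2-fold higher number from compound 2 to compound 3 (0.08 log units; within the scatter). Compound 4 `CCCCCCCCn1cc(/C=C/C(=O)c2ccc(NC(=O)CN3CCC(Cc4ccccc4)CC3)cc2)nn1` arises from compound 1 by the same change, (hydrogen in place of ethyl on a saturated chain carbon, eight bonds along the chain from an aromatic nitrogen). Because the measured step of a 1.2-fold higher number from compound 2 to compound 3 (0.08 log units; within the scatter) stayed within the scatter, the step from compound 1 to compound 4 is expected to be small as well, about a 1.2-fold higher number from compound 1 to compound 4 (0.07 log units; within the scatter). Compound 4 is therefore estimated at 80000 nM in this assay, expected to fall between 35000 nM and 200000 nM.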

Compound 4, half-maximal inhibitory concentration: 43800 nM
Compound 4: middle estimate off by 1.8-fold (0.26 log units), on the high side, and the stated range covers the measured number.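

Replacing ethyl with hydrogen on the core of compound 1 gives, in this assay, a 1.5-fold lower number from compound 1 to compound 4 (0.19 log units; within the scatter). The same change therefore gives steps that cannot be told apart on the two cores: the same change on two cores in this assay, a 1.2-fold higher number (0.08 log units; within the scatter) from compound 2 to compound 3 and a 1.5-fold lower number (0.19 log units; within the scatter) from compound 1 to compound 4, 1.8-fold (0.27 log units) apart, within the scatter of two such steps This shows that the change, at this place on the chain, carried over between these two cores without a step beyond the scatter, but two pairs in a single assay do not show that it would stay this small on any other core.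

The compounds shown leave open what a much shorter chain would do. They also leave open what an amine or a carboxylic acid in place of the chain would do on either core.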